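A few compounds are considered here, and "the series" means these few. Any claim that something is new, unique, unknown or untested is made for them only; others in the source may bear on it.

In a functional assay on HOS-TE85 cells (Homo sapiens) for inhibition, read by CCK-8 assay, with a stated time of 72 h (a higher number here means a weaker inhibitor, a lower number a stronger inhibitor), compound 2 `O=C(NCCCCc1ccccc1)c1cccc(C2SCC(=O)N2c2ccccc2)c1` gives 15.9 nM, and compound 1 `COc1ccc(C)cc1N1C(=O)CSC1c1cccc(C(=O)NCCCCc2ccccc2)c1` gives 300 nM. Compound 3 `COc1cccc(OC)c1N1C(=O)CSC1c1cccc(C(=O)NCCCCc2ccccc2)c1` gives > 1000 nM, which is a limit of the assay and not a number, and it is the weakest of the three. Compound 4 `O=C(NCCCCc1ccccc1)c1cccc(C2SCC(=O)N2c2ccc(C3CC3)cc2)c1` alters the same place on the shared core: 4-cyclopropylphenyl in place of 2,6-dimethoxyphenyl on an amide-type nitrogen in a ring. For the measured compounds named here, three measured steps bear on this change at that place: an at least 62-fold higher number from compound 2 to compound 3 (1.79 log units; beyond the scatter), an at least 3.3-fold higher number from compound 1 to compound 3 (0.52 log units; beyond the scatter) and a 19-fold lower number from compound 1 to compound 2 (1.28 log units; beyond the scatter). Compound 4 drops the 2,6-dimethoxyphenyl group of compound 3, but unlike compound 2 it keeps a group on its phenyl, so a large move towards a lower number is expected, stopping short of compound 2. The expected size is an at least 16-fold lower number from compound 3 to compound 4 (1.22 log units; beyond the scatter). For compound 4 the estimate is 60 nM, within an expected range of 12 nM to 300 nM.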

Compound 4, half-maximal inhibitory concentration: 217 nM
Beside the measured number, compound 4's estimate is 3.6-fold (0.56 log units) below it; low and high end bracket the measured number.
By their numbers in this assay, from the lowest: compound 2; then compounds 4 and 1 (each within the scatter of the next). At a limit, above all of these: compound 3.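

In this assay there is an at least 4.6-fold lower number from compound 3 to compound 4 (0.66 log units; beyond the scatter) when the 2,6-dimethoxyphenyl group goes, but compound 3 stands at a limit of the assay and not at a number: the limit of > 1000 nM in this assay, at which 1 of the 4 values shown sits. Cyclopropyl on the plain phenyl brings a 14-fold higher number from compound 2 to compound 4 (1.14 log units; beyond the scatter) so a group other than methoxy on this phenyl can also raise the number. With a 1.4-fold lower number from compound 1 to compound 4 (0.14 log units; within the scatter) the 4-cyclopropylphenyl and 2-methoxy-5-methylphenyl groups cannot be told apart.

Going by these compounds, whether a phenyl carrying a fluorine, an amine or a carboxylic acid in place of the cyclopropyl would stay closer to compound 2 remains open.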